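Benzylamide in place of the tolyl amide

A few compounds are considered here, and "the series" means these few. Any claim that something is new, unique, unknown or untested is made for them only; others in the source may bear on it.

Compound 1, `Cc1ccc(NC(=O)C2CCN(C/C=C/c3ccccc3)CC2)cc1`: in a functional assay on MCF7 cells (Homo sapiens) for inhibition, read by MTT assay, with a stated time of 72 h (a higher number here means a weaker inhibitor, a lower number a stronger inhibitor), compound 1 gives 30000 nM.
Compound 2, `COc1ccc(NC(=O)C2CCN(C/C=C/c3ccccc3)CC2)cc1`: in this assay compound 2 reaches only a limit of the measurement, > 100000 nM.
Compound 3, `O=C(Nc1cccc(F)c1)C1CCN(C/C=C/c2ccccc2)CC1`: in this assay compound 3 gives 33000 nM.

Among the numbers shown, compound 1 holds the lowest, though its gap to compound 3, a 1.1-fold higher number from compound 1 to compound 3 (0.04 log units; within the scatter), lies within the scatter, so the two cannot be told apart. Compound 2 stands at a limit, (the limit of > 100000 nM in this assay, at which 1 of the 3 values shown sits), and the step of an at least 3.3-fold higher number from compound 1 to compound 2 (0.52 log units; beyond the scatter) is the only one of the three that clearly moves the number.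

Compound 4, `O=C(NCc1ccccc1)C1CCN(C/C=C/c2ccccc2)CC1`, is not yet measured. It differs from compound 1 by benzyl in place of 4-methylphenyl on an amide-type nitrogen. For the measured compounds named here, no measured step swaps the aryl for a benzyl on the amide-type nitrogen; the known steps concern only substituents on the aryl ring, one of them, an at least 3.0-fold lower number from compound 2 to compound 3 (0.48 log units; beyond the scatter), again beyond the scatter. These steps give no direction for the present change, so the expectation for this assay rests on compound 1 itself, with a wide range that allows for weakening of the kind compound 2 showed. Compound 4 is estimated at 40000 nM, between 15000 nM and 100000 nM, which means an expected step of a 1.3-fold higher number from compound 1 to compound 4 (0.12 log units; within the scatter).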

Compound 4, half-maximal inhibitory concentration: > 100000 nM
Compound 4 was reported as a limit; the forecaster's own chance of this, stated with the estimate: 30%; at least 2.5-fold (0.39 log units) between middle value and limit.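

Until now only substituents on the aryl ring had changed, whereas here the group on the amide-type nitrogen is itself replaced. Although benzyl and 4-methylphenyl have the same count of heavy atoms, this assay shows an at least 3.3-fold higher number from compound 1 to compound 4 (0.52 log units; beyond the scatter), and the swap from the fluorinated aryl amide shows an at least 3.0-fold higher number from compound 3 to compound 4 (0.48 log units; beyond the scatter), so this position responds to more than substituents on the aryl ring. Compound 4 stands at a limit of the assay rather than at a number, and the step between it and compound 2, also at a limit, cannot be read: the limit of > 100000 nM in this assay, at which 2 of the 4 values shown sit.

The compounds shown leave open whether a plain phenyl or a longer chain such as phenylethyl on the same amide-type nitrogen would stay close to compound 1 or fall to the same limit. They also do not tell how far compound 4 lies beyond its limit, nor whether an amine or a carboxylic acid on the benzyl ring would bring a readable number back.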